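The source may hold more compounds than are shown below. What is called first, only, known or untested is meant among the compounds shown, and "the series" means these compounds.

Compound 1 `C=CC1=C(C(=O)NCc2ccccc2)C(c2ccc(OC)c(OC)c2)OC1`, compound 2 `C=CC1=C(C(=O)NCc2ccccc2)C(c2ccc(OC)cc2)OC1` and compound 3 `C=CC1=C(C(=O)Nc2ccccc2OC)C(c2ccc(Cl)c(Cl)c2)OC1` share one core. In a functional assay on QGY7701 cells (Homo sapiens) for cytotoxicity, read by MTT assay, with a stated time of 24 h (a higher number here means a weaker inhibitor, a lower number a stronger inhibitor), compound 1 gives only the limit > 100000 nM. Compound 2 likewise gives only the limit > 100000 nM. Compound 3 also reaches only the limit > 100000 nM. Compound 2 thus stands at a limit, with no number of its own; the evidence so far is the limit of > 100000 nM in this assay, at which 3 of the 3 values shown sit. Compound 4 `C=CC1=C(C(=O)NCCCCC)C(c2ccc(OC)cc2)OC1` differs from compound 2 by butyl in place of phenyl on a saturated chain carbon bound to an amide-type nitrogen. Going by the values given here, the single step between measured compounds, a step that the two limits leave unreadable from compound 1 to compound 2, is unreadable from two limits and concerns a methoxy on an aromatic carbon, not the amide side, so it gives no size for this change. Among the compounds with values here, no measured step bears on the benzylamino-to-pentylamino exchange. Compound 4 is expected to stay at or near the limit, the expected step being a step that the limit leaves unreadable from compound 2 to compound 4. The estimate for compound 4 is 150000 nM, within 40000 nM to 600000 nM.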

Compound 4, half-maximal inhibitory concentration: > 100000 nM
Compound 4: no number, only a limit; the forecaster's own chance of this, stated with the estimate: 80%; the middle value does not contradict the limit.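

Compound 4 gives only a limit, > 100000 nM, in this assay. Compound 2 also gives only a limit, > 100000 nM. No step can be read between compound 2 and compound 4. The compounds shown leave open whether any change on the shared core gives a measurable value in this assay.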